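Piperidin-1-yl replaces methylamino in compound 1

The source may report more compounds than this note shows. Statements on the series, on what has been measured and on what is new or still open speak of the compounds shown alone.

In a physicochemical assay for solubility, in phosphate buffer, at pH 7.4 (on this read-out lower numbers stand for lower solubility and higher numbers for higher solubility), compound 1 `CNC(=O)CN1CCC(c2cc3c(-c4ccc(=O)n(C(C)C)c4)ccnc3[nH]2)CC1` gives 34000 nM and stands highest of the three measured numbers. Compound 3 `COc1cc(C(=O)N2CCCC2)ccc1-c1ccnc2[nH]c(C3CCOCC3)cc12` gives 15000 nM and compound 2 `CC(C)n1nc(-c2ccnc3[nH]c(C4CCN(CC(=O)N(C)C)CC4)cc23)ccc1=O` gives 11000 nM so both lie lower, beyond the scatter. Compound 4 `CC(C)n1cc(-c2ccnc3[nH]c(C4CCN(CC(=O)N5CCCCC5)CC4)cc23)ccc1=O` has piperidin-1-yl in place of methylamino on a carbonyl carbon and otherwise matches compound 1. For the measured compounds named here, no measured pair differs in one place only, so this change has no direct measure here. A downward step beyond the scatter is expected in this assay, a cautious guess guided only by compound 1 at 34000 nM sitting at the top of the measured numbers. The estimated change is a 2.8-fold lower number from compound 1 to compound 4 (0.45 log units; beyond the scatter) overall. Compound 4 is expected at 12000 nM with an estimated range from 3500 nM to 35000 nM in this measurement.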

Compound 4, solubility: 79000 nM
The estimate for compound 4 lay 6.6-fold (0.82 log units) below the measured number; measured number outside the range, above it.
By their numbers in this assay, from the lowest: compounds 2 and 3 (each within the scatter of the next); then compound 1; then compound 4.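

In this assay, the change at this carbonyl carbon can now be read on its own: a 2.3-fold higher number from compound 1 to compound 4 (0.37 log units; beyond the scatter) is a modest step beyond the scatter. Piperidin-1-yl, which has no hydrogen-bond donor and more heavy atoms than methylamino, goes with a higher number here, not a lower one. Nothing measured here bears on the reason for this step.

From the compounds shown here alone, whether morpholin-4-yl or open-chain diethylamino on the same carbonyl carbon would follow piperidin-1-yl remains open. The compounds shown also cannot separate the loss of the amide hydrogen from the gain of the ring.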